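Swapping the Acyl Group on a Shared Piperidine Amide Core

The compounds below may be only part of what the source reports. "The series", "measured", "known", "first", "only" and "open" are said of these compounds alone.

Measured compounds:
compound 1 `CC(C)[C@@H](NC(=O)CC1CC1)C(=O)N1CCC(c2ccc(Cl)cc2)CC1` — 46 nM
compound 2 `CC(C)[C@@H](NC(=O)c1nc2ccccc2s1)C(=O)N1CCC(c2ccc(Cl)cc2)CC1` — 18 nM

Of the compounds shown here, two have been tested in an assay on THP-1 cells for displacement of a labelled ligand from C-C chemokine receptor type 1 (Homo sapiens); a higher number here means a weaker inhibitor, a lower number a stronger inhibitor. Compound 1 `CC(C)[C@@H](NC(=O)CC1CC1)C(=O)N1CCC(c2ccc(Cl)cc2)CC1` gives 46 nM, and compound 2 `CC(C)[C@@H](NC(=O)c1nc2ccccc2s1)C(=O)N1CCC(c2ccc(Cl)cc2)CC1` gives 18 nM. Compound 2 therefore holds the lower of the two numbers, with the step of a 2.6-fold lower number from compound 1 to compound 2 (0.41 log units; beyond the scatter) being modest but beyond the scatter. That single step is the only one on record, and it shows that a 1,3-benzothiazol-2-yl group on the carbonyl carbon gave a lower number than cyclopropylmethyl.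

Compound 3 `Cc1cccc(CCC(=O)N[C@@H](C(=O)N2CCC(c3ccc(Cl)cc3)CC2)C(C)C)c1` has not yet been measured. It differs from compound 2 as follows: 2-(3-methylphenyl)ethyl in place of 1,3-benzothiazol-2-yl on a carbonyl carbon. The entering group resembles the cyclopropylmethyl of compound 1 in being joined to the carbonyl through saturated carbons, while carrying an aromatic ring further out. For the measured compounds named here, no measured step describes exactly this change, so the only guide is the step from compound 1 to compound 2, which the change in compound 3 partly reverses.

Compound 3 is therefore expected to show a step of a 2.2-fold higher number from compound 2 to compound 3 (0.35 log units; beyond the scatter) in this assay, moving back toward the number of compound 1. The estimate for compound 3 is 40 nM, within a range from 15 nM to 120 nM.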

Compound 3, half-maximal inhibitory concentration: 22 nM
Beside the measured number, compound 3's estimate is 1.8-fold (0.26 log units) above it, within the range that was stated.
By their numbers in this assay, from the lowest: compounds 2 and 3 (each within the scatter of the next); then compound 1.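

In this assay, the benzothiazole with its 2 hydrogen-bond acceptors and the all-carbon 2-(3-methylphenyl)ethyl group, which has none, are not told apart on a carbonyl carbon whose other neighbour is an amide-type nitrogen: the change gives a 1.2-fold higher number from compound 2 to compound 3 (0.09 log units; within the scatter) and so lies within the scatter. Hetero atoms in the group at this place are therefore not needed to stay level with compound 2, and neither is an aromatic ring joined straight to the carbonyl, which the earlier pair could not separate from the difference between a ring-bearing group and cyclopropylmethyl. Carrying an aromatic ring further out on the saturated chain also counts here, since 3-methylbenzyl in place of cyclopropyl gives a 2.1-fold lower number from compound 1 to compound 3 (0.32 log units; beyond the scatter), a modest step beyond the scatter, though nothing on record explains why these groups compare as they do.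

The compounds shown leave open whether the methyl on the ring of compound 3 plays any part, which a plain 2-phenylethyl group would test. They also leave open how far the chain can stretch or the ring can change, as with a 3-phenylpropyl group or a carboxylic acid on that ring.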